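The compounds below may be only part of what the source reports. "The series", "measured", "known", "first", "only" and "open" are said of these compounds alone.

Measured so far in an ADME assay on L929 cells (Mus musculus) for cytotoxicity, read by resazurin assay, with a stated time of 72 h (a higher number here means a weaker inhibitor, a lower number a stronger inhibitor), each entry a limit of the assay and not a number:

- compound 1 `CCc1ccc(C(=O)/C=C/c2ccc3c(c2)B(O)OC3)cc1` gives > 10 ug/mL as a limit
- compound 2 `O=C(/C=C/c1ccc2c(c1)B(O)OC2)c1ccc(F)cc1` gives > 10 ug/mL as a limit
- compound 3 `O=C(/C=C/c1ccc2c(c1)B(O)OC2)c1ccc(Cl)cc1` gives > 10 ug/mL as a limit

Compound 3 stands at > 10 ug/mL which is a limit and not a number. The set as a whole shows the limit of > 10 ug/mL in this assay, at which 3 of the 3 values shown sit, with no numeric value yet.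

Compound 4 `CCOC(=O)c1ccc(C(=O)/C=C/c2ccc3c(c2)B(O)OC3)cc1` carries the change ethoxycarbonyl in place of chloro on an aromatic carbon in the form of ethoxycarbonyl in place of chloro on an aromatic carbon. Among the measured compounds shown here, three measured steps bear on it by changing the group at that place: a step that the two limits leave unreadable from compound 1 to compound 2 and a step that the two limits leave unreadable from compound 1 to compound 3 and a step that the two limits leave unreadable from compound 2 to compound 3 give no size to carry over. No step beyond the scatter is therefore expected in this assay on these data. The expected step is a step that the limit leaves unreadable from compound 3 to compound 4 with no direction taken from the limits. Compound 4 is expected to report a limit as well. Should a number appear, the estimate for compound 4 is 12 ug/mL with an expected range from 5 ug/mL to 30 ug/mL as its span.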

Compound 4, half-maximal inhibitory concentration: > 10 ug/mL
Compound 4 gave a limit, no number; the forecaster's own chance of this, stated with the estimate: 75%; the middle value lies beyond the limit too.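

In this assay compound 4 gives > 10 ug/mL, a limit and not a number, so its steps from compound 1, compound 2 and compound 3 cannot be read. The compounds shown leave open whether any group at this place on the shared core gives a numeric value in this assay: the limit of > 10 ug/mL in this assay, at which 4 of the 4 values shown sit.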